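Two Chlorines for One Fluorine on the Benzyl Ether

The source may hold more compounds than are shown below. What is called first, only, known or untested is meant among the compounds shown, and "the series" means these compounds.

Measured so far:
Compound 1, `COc1cc(CNCc2ccncc2)ccc1OCc1ccccc1F`: 5100 nM
Compound 2, `COc1cc(CNCCSc2nnnn2C)ccc1OCc1ccc(Cl)nc1`: 86000 nM
Compound 3, `COc1cc(CNCCNc2ccnc3cc(Cl)ccc23)ccc1OCc1ccc(Cl)nc1`: 2700 nM

These numbers come from a functional assay on HeLa cells (Homo sapiens) for inhibition, with a stated time of 72 h; on this read-out higher numbers stand for an effect only at larger amounts of compound and lower numbers for an effect already at smaller amounts. Compound 1 sits second highest of the three; its nearest neighbour is compound 3, whose number differs by less than the usual scatter, while compound 2 lies far away, beyond the scatter. Compound 4, `COc1cc(CNCc2ccncc2)ccc1OCc1ccc(Cl)cc1Cl`, is not yet measured. It differs from compound 1 in one place: 2,4-dichlorophenyl in place of 2-fluorophenyl on a saturated chain carbon bound to an oxygen on an aromatic ring. Among the measured compounds shown here, no measured pair shows this change, so there is no step to lean on. The expectation is a small move toward a lower number, of a size that may not clear the scatter; in this assay the expected step is a 1.7-fold lower number from compound 1 to compound 4 (0.23 log units; within the scatter). Compound 4 is therefore estimated at about 3000 nM, within a range from 800 nM to 12000 nM.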

Compound 4, half-maximal effective concentration: 3900 nM
Compound 4: middle estimate off by 1.3-fold (0.11 log units), on the low side, within the range that was stated.
By their numbers in this assay, from the lowest: compounds 3, 4 and 1 (each within the scatter of the next); then compound 2.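

In this assay, among the compounds shown here, this is the first direct reading of the group on a saturated chain carbon bound to an oxygen on an aromatic ring: 2,4-dichlorophenyl in place of 2-fluorophenyl gives a 1.3-fold lower number from compound 1 to compound 4 (0.12 log units; within the scatter), a step within the scatter. With the rest of the core kept the same, this swap therefore produces no difference that can be told apart from repeat variation. Nothing available bears on why. Still open, going by these compounds, is whether a plain phenyl without any halogen, or a phenyl carrying a carboxylic acid, would give a number clearly apart from these.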